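This account rests on a few compounds, and the source may have more. Where it says the series, first, only, none or still open, it means among the compounds named here.

Measured so far in a functional assay on ileum for inhibition of histamine H1 receptor (Cavia porcellus); on this read-out lower numbers stand for stronger inhibition and higher numbers for weaker inhibition:
- compound 1 `CCCOCCn1c(N2CCN(C)CC2)nc2ccccc21`: 20 nM
- compound 2 `CCOCCn1c(N2CCN(CC)CC2)nc2ccccc21`: 18 nM

For the measured compounds named here, compound 1 and compound 2 share the same core and differ at two places at once, so no single step between them can be read; their two numbers in this assay lie within the usual scatter of each other, and neither compound can be set apart from the other on this evidence.

Compound 3 `CN1CCN(c2nc3ccccc3n2CCOCCO)CC1` has not yet been measured in this assay. It departs from compound 1 by one change: hydroxy in place of methyl on a saturated chain carbon, two bonds along the chain from an oxygen on a saturated carbon. Going by the values given here, no measured pair in this set shows what such a change does on this read-out, so the expectation rests on the structures alone. The step from compound 1 to compound 3 is expected to be a 2.0-fold higher number from compound 1 to compound 3 (0.30 log units; within the scatter), a modest move toward weaker inhibition that may still fall within the scatter. For compound 3 the estimate in this assay is 40 nM, with a likely range from 12 nM to 130 nM.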

Compound 3, half-maximal inhibitory concentration: 42 nM
Beside the measured number, compound 3's estimate is 1.1-fold (0.02 log units) below it; low and high end bracket the measured number.
By their numbers in this assay, from the lowest: compounds 2 and 1 (each within the scatter of the next); then compound 3.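

Hydroxy in place of methyl on a saturated chain carbon, two bonds along the chain from an oxygen on a saturated carbon, gives the first single step that can be read in this assay: a 2.1-fold higher number from compound 1 to compound 3 (0.32 log units; beyond the scatter). Read one bond further out, as propoxy to 2-hydroxyethoxy, this shows that the position responds to the change, though only modestly, with inhibition moving toward weaker values. Nothing available gives a reason for this step.

From the compounds shown here alone, whether the same shift would follow from a different group at this position, such as an amine, a carboxylic acid or a methoxy, remains open. Also open, going by these compounds, is how a longer chain would read here, and one step alone cannot show whether the effect holds on any other compound of this core.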